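Chloro to iodo on the anilide series

The source may report more compounds than this note shows. Statements on the series, on what has been measured and on what is new or still open speak of the compounds shown alone.

Measured in a functional assay on U-937 cells (Homo sapiens) for antiproliferative activity, with a stated time of 48 h; a lower number here means that less compound is needed, a higher number that more compound is needed for the effect:
- compound 1 `Nc1ccc(NC(=O)CCCCCCC(=O)NO)cc1`: 6400 nM
- compound 2 `O=C(CCCCCCC(=O)Nc1ccc(O)cc1)NO`: 6400 nM
- compound 3 `O=C(CCCCCCC(=O)Nc1ccc(Cl)cc1)NO`: 550 nM

Compound 3 has the lowest of the three numbers in this assay. The next structure is compound 4 `O=C(CCCCCCC(=O)Nc1ccc(I)cc1)NO`, with iodo in place of chloro on an aromatic carbon.

Three measured steps change this same place. Two are large and bring chloro in: a 12-fold lower number from compound 1 to compound 3 (1.07 log units; beyond the scatter) and a 12-fold lower number from compound 2 to compound 3 (1.07 log units; beyond the scatter). The third, no change at the digits printed from compound 1 to compound 2 (within the scatter), stays within the scatter. Among the compounds with values here, no measured compound carries iodo, and no step shows this exchange directly, so these steps bear on it only indirectly. Neither large step is taken as a guide to its size, and no step beyond the scatter is expected in this assay. The expectation is anchored on compound 3 at 550 nM, and a direction cannot be assigned with confidence.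

The expected change is a 1.1-fold lower number from compound 3 to compound 4 (0.06 log units; within the scatter). For compound 4 the estimated value is 480 nM, with an expected range from 170 nM to 1400 nM.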

Compound 4, half-maximal effective concentration: 120 nM
Compound 4: middle estimate off by 4.0-fold (0.60 log units), on the high side, outside the stated range (below it).
By their numbers in this assay, from the lowest: compound 4; then compound 3; then compounds 1 and 2 (each within the scatter of the next).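

In this assay, a step of a 4.6-fold lower number from compound 3 to compound 4 (0.66 log units; beyond the scatter) shows that at this position the choice of halogen matters, and not only the presence of one: the number moves beyond the scatter although chloro and iodo each count as one heavy atom, with no hydrogen-bond donors or acceptors and no net charge. The gain from chloro to iodo adds to what chloro already gave over the hydroxy and amino compounds, so the steps of a 53-fold lower number from compound 2 to compound 4 (1.73 log units; beyond the scatter) and a 53-fold lower number from compound 1 to compound 4 (1.73 log units; beyond the scatter) are the largest at this place among the four compounds. Nothing measured here accounts for the difference between iodo and chloro.

Open, on these data alone, is whether fluoro or bromo would fall in line with the change from chloro to iodo, and whether a methyl or trifluoromethyl group at this place would match iodo. Also open, as far as these compounds go, is whether the iodo gain would hold on a shorter or longer chain.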